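Cytotoxicity working notes: from compound 2 toward compound 3

The compounds below may be only part of what the source reports. "The series", "measured", "known", "first", "only" and "open" are said of these compounds alone.

Measured so far in an ADME assay on A549 cells (Homo sapiens) for cytotoxicity, read by MTT assay, with a stated time of 48 h; on this read-out higher numbers stand for weaker inhibition and lower numbers for stronger inhibition:
compound 1, `Cc1nc2ccccc2cc1C(=O)n1nc(C)c(C2CCCCO2)c1C`, gives 143 ug/mL
compound 2, `Cc1ccc(-c2nnc(-c3cc4ccccc4nc3C)o2)cc1`, gives 175 ug/mL

Among the compounds with values here, compound 2 holds the higher of the two numbers so far. Its nearest neighbour is compound 1, whose value lies within the usual scatter of it, so the two compounds cannot be placed in any order on this assay; both read as weakly cytotoxic.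

Compound 3, `Cc1nc2ccccc2cc1-c1nnc(-c2ccc(OC(F)(F)F)cc2)o1`, is the next member to be tested. Relative to compound 2 the change is trifluoromethoxy in place of methyl on an aromatic carbon; the rest of the molecule, including the shared core of compound 2, is untouched. Within the data shown here, no pair of measured compounds separated by a single change is available, so no measured step can anchor this one.

For compound 3 the step of a 1.2-fold lower number from compound 2 to compound 3 (0.07 log units; within the scatter) is expected to be small, with no direction called beyond the scatter, because compound 2 itself gives 175 ug/mL and compound 1 sits close by. Compound 3 is therefore estimated at 150 ug/mL, within a range from 75 ug/mL to 300 ug/mL, pending the measurement.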

Compound 3, half-maximal inhibitory concentration: 91.1 ug/mL
The estimate for compound 3 lay 1.6-fold (0.22 log units) above the measured number; low and high end bracket the measured number.
By their numbers in this assay, from the lowest: compounds 3, 1 and 2 (each within the scatter of the next).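

In this assay, the series now has its first step in one place: a 1.9-fold lower number from compound 2 to compound 3 (0.28 log units; within the scatter), with trifluoromethoxy in place of methyl on an aromatic carbon, para to a large group. This position on the six-membered aromatic ring of carbon only thus carries either group, the one with more heavy atoms and an added oxygen and fluorine included, with a difference that stays inside the usual scatter of repeated measurements, although close to its edge. No measurement is available that bears on the origin of this small difference.

From the compounds shown here alone, whether an amine, a carboxylic acid or a longer alkyl chain at the same aromatic carbon would stay within the scatter of compound 2, or move beyond it, remains open. The compounds shown offer only one step at this position, and it is still open whether any group placed there gives a difference beyond the scatter, in either direction, on this read-out.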